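Benzyl for cyclohexyl on the ring nitrogen of compound 3

A few compounds are considered here, and "the series" means these few. Any claim that something is new, unique, unknown or untested is made for them only; others in the source may bear on it.

Of the compounds shown here, three have been measured in a functional assay on HT-29 cells (Homo sapiens) for inhibition, read by sulforhodamine B assay, with a stated time of 48 h, tested at 10 uM; a higher number here means more inhibition at the concentration tested (going by the name of the read-out), a lower number less inhibition. Compound 1 `Brc1ccc(-c2cn3ccnc3c(-c3ccc4ncn(C5CCCCC5)c4c3)n2)cc1` gives 20.9%, and compound 2 `c1ccc(Cn2cnc3ccc(-c4nc(-c5cccc6ccccc56)cn5ccnc45)cc32)cc1` gives 18.6%. Compound 3 `c1cn2cc(-c3ccc4c(c3)ncn4C3CCCCC3)nc(-c3ccc4ncn(C5CCCCC5)c4c3)c2n1` gives 58.2%, the highest of the three numbers, beyond the scatter above both compound 1 and compound 2.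

Compound 4 `c1ccc(Cn2cnc3ccc(-c4nc(-c5ccc6c(c5)ncn6C5CCCCC5)cn5ccnc45)cc32)cc1` is not yet measured. It differs from compound 3 in one place: benzyl in place of cyclohexyl on an aromatic nitrogen. Within the data shown here, no step between two measured compounds isolates this change, so its size and direction are open. Compound 2, which carries the benzyl, stands low, while compound 3 with two cyclohexyl groups stands high, so a downward step is expected, of moderate size, possibly none beyond the scatter, as a number 14.2 percentage points lower from compound 3 to compound 4 (beyond the scatter). Compound 4 is estimated at 44%, in the range 24% to 64%.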

Compound 4, a percentage reported as inhibition, at one concentration (the size of the read-out at that concentration, not a potency): -48.7%
Estimate against measurement, compound 4: 92.7 percentage points above, and the stated range ends above it.
By their numbers in this assay, from the lowest: compound 4; then compounds 2 and 1 (each within the scatter of the next); then compound 3.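

Benzyl in place of cyclohexyl on the aromatic nitrogen gives, in this assay, a number 106.9 percentage points lower from compound 3 to compound 4 (beyond the scatter), so this position is far from indifferent to the group it carries. Compound 4 at -48.7% stands below zero, a change of sign and not only a loss of inhibition. Among these compounds, nothing measured so far bears on why this change has so large an effect.

Open, as far as these compounds go, is how a methyl, a phenethyl or an aminoethyl chain on this nitrogen would read, and whether benzyl on the other cyclohexyl-bearing nitrogen of compound 3 gives a step of like size.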